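A few compounds are considered here, and "the series" means these few. Any claim that something is new, unique, unknown or untested is made for them only; others in the source may bear on it.

Compound 1 `CC(C)(C)NC(=O)N1CC1C#N` carries a tert-butyl group on its urea nitrogen; in a functional assay on WiDr cells (Homo sapiens) for inhibition (on this read-out higher numbers stand for weaker inhibition and lower numbers for stronger inhibition), compound 1 gives 180000 nM. Compound 2 `N#CC1CN1C(N)=O` has hydrogen on that nitrogen instead. In this assay compound 2 gives > 280000 nM, which is a limit of the assay and not a number. Compound 2 therefore stands at the limit of > 280000 nM in this assay, at which 1 of the 2 values shown sits, so its exact place among the values shown is not known. Among the measured compounds shown here, the only measured step is an at least 1.5-fold higher number from compound 1 to compound 2 (0.19 log units; that floor lies within the scatter). Compound 3 `CCNC(=O)N1CC1C#N` differs from compound 2 by ethyl in place of hydrogen on an amide-type nitrogen. This change runs in the opposite direction to the measured step, restoring an alkyl group to the same nitrogen, and that step was small, so compound 3 is expected to land near compound 1 or between compound 1 and the limit, which means an expected step of an at least 1.4-fold lower number from compound 2 to compound 3 (0.14 log units; that floor lies within the scatter). In this assay compound 3 is estimated at 200000 nM, with a range from 80000 nM to 500000 nM.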

Compound 3, half-maximal inhibitory concentration: 4000 nM
Beside the measured number, compound 3's estimate is 50-fold (1.70 log units) above it, and the stated range ends above it.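

In this assay, the group on this amide-type nitrogen turns out to matter far more than the earlier pair could show, with ethyl in place of hydrogen giving an at least 70-fold lower number from compound 2 to compound 3 (1.84 log units; beyond the scatter) and ethyl in place of tert-butyl giving a 45-fold lower number from compound 1 to compound 3 (1.65 log units; beyond the scatter). Compound 3 is thus the most potent of the three, so the number does not simply follow the size of the group: the smallest and the largest groups shown both give weaker inhibition than ethyl. The step from compound 2 is only a floor, as compound 2 is held at a limit of the assay and not a number: the limit of > 280000 nM in this assay, at which 1 of the 3 values shown sits.

The compounds shown leave open how the number moves with methyl, isopropyl or a longer chain on this nitrogen. They also leave open whether an amine or a carboxylic acid at the end of the ethyl chain would keep the inhibition seen with compound 3.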